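The source may report more compounds than this note shows. Statements on the series, on what has been measured and on what is new or still open speak of the compounds shown alone.

Three compounds of one shared core have been run in a functional assay on HT-29 cells (Homo sapiens) for inhibition, read by sulforhodamine B assay, with a stated time of 48 h, tested at 10 uM; on this read-out lower numbers stand for a stronger effect and higher numbers for a weaker effect at the one concentration tested. Compound 1 `COc1cc(Cl)cc(-c2nn(-c3cccc(NC(=O)c4ccc(Cl)c(Cl)c4)c3)cc2-c2ccncc2)c1` gives 56.4% in this assay, compound 2 `O=C(Nc1cccc(-n2cc(-c3ccncc3)c(-c3cc(O)cc(Cl)c3)n2)c1)Nc1ccc(Cl)c(C(F)(F)F)c1` gives 35.3%, and compound 3 `COc1cc(Cl)cc(-c2nn(-c3cccc(NC(=O)Nc4cc(C(F)(F)F)cc(C(F)(F)F)c4)c3)cc2-c2ccncc2)c1` gives 3.93%, the lowest of the three numbers, with both other values lying beyond the scatter above it. Compound 4 `COc1cc(Cl)cc(-c2nn(-c3cccc(NC(=O)Nc4cccc(C(F)(F)F)c4)c3)cc2-c2ccncc2)c1` has not yet been measured in this assay. It differs from compound 3 in one place: hydrogen in place of trifluoromethyl on an aromatic carbon. Within the data shown here, no pair of measured compounds differs in one place, so nothing directly sets the size of this step. Because compound 2, which also carries one trifluoromethyl on that ring, gives 35.3%, the number for compound 4 is expected to rise in this assay, by a step of a number 26.1 percentage points higher from compound 3 to compound 4 (beyond the scatter) beyond the scatter. Compound 4 is estimated at 30%, within 8% to 60%.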

Compound 4, a percentage reported as activity, at one concentration (the size of the read-out at that concentration, not a potency): 5.75%
Estimate against measurement, compound 4: 24.3 percentage points above; the measured number lies below the stated range.
By their numbers in this assay, from the lowest: compounds 3 and 4 (each within the scatter of the next); then compound 2; then compound 1.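

In this assay, taking away one trifluoromethyl gives a number 1.8 percentage points higher from compound 3 to compound 4 (within the scatter), so this second trifluoromethyl is not needed to hold the read-out on the shared core. The larger change, (3-(trifluoromethyl)phenyl)amino in place of 3,4-dichlorophenyl on a carbonyl carbon, gives a number 50.7 percentage points lower from compound 1 to compound 4 (beyond the scatter). Nothing shown here explains either step. From the compounds shown here alone, what stays open is whether an amine or a nitrile at this aromatic carbon would hold the read-out as well, and whether the remaining trifluoromethyl can itself be replaced by hydrogen.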